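From Trifluoromethyl to Methoxy in Growth Inhibition

This account rests on a few compounds, and the source may have more. Where it says the series, first, only, none or still open, it means among the compounds named here.

In a functional assay on MCF7 cells (Homo sapiens) for inhibition, read by sulforhodamine B assay (on this read-out higher numbers stand for weaker inhibition of growth and lower numbers for stronger inhibition of growth), compound 2 (`FC(F)(F)c1ccc(-c2ccc(-c3ccc(-c4nc5ccccc5[nH]4)cc3)cc2)cc1`) stands highest of the two measured compounds at 41400 nM and compound 1 (`Cc1ccc2[nH]c(-c3ccc(-c4ccc(-c5ccc(N(C)C)cc5)cc4)cc3)nc2c1`) gives 3130 nM in the same read-out. The number of compound 1 is the lower one, and the gap between the two lies beyond the scatter. Compound 3 (`COc1ccc(-c2ccc(-c3ccc(-c4nc5ccccc5[nH]4)cc3)cc2)cc1`) carries methoxy in place of trifluoromethyl on an aromatic carbon para to a large group. For the measured compounds named here, no measured pair shows this change alone, so compound 1 at 3130 nM is the only lower reference. In this assay a moderate fall beyond the scatter is expected, estimated as a 3.5-fold lower number from compound 2 to compound 3 (0.54 log units; beyond the scatter) (toward stronger inhibition). For compound 3 the estimated value is 12000 nM (expected range 3500 nM to 40000 nM).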

Compound 3, concentration for 50% growth inhibition: 33300 nM
For compound 3 the middle estimate is 2.8-fold (0.44 log units) below the measured one; the range from low to high includes it.
By their numbers in this assay, from the lowest: compound 1; then compounds 3 and 2 (each within the scatter of the next).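

At this place, on an aromatic carbon para to a large group, methoxy in place of trifluoromethyl gives a 1.2-fold lower number from compound 2 to compound 3 (0.09 log units; within the scatter) in this assay and so does not separate the two groups on this read-out. This holds although the two groups differ in heavy atoms and only methoxy carries a hydrogen-bond acceptor. No evidence on hand bears on this result. Going by these compounds, what a carboxylic acid or a primary amine would give in this place stays open. The compounds shown also leave unresolved which of the differences between compound 1 and compound 3 matters in this assay.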